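The source may report more compounds than this note shows. Statements on the series, on what has been measured and on what is new or still open speak of the compounds shown alone.

In an in vitro ADME assay on microsomes (Homo sapiens) for metabolic stability (a higher number here means that the compound lasts longer, a lower number that the compound disappears faster), compound 1 (`CCOc1nc(-c2ccc(Cl)cc2Cl)c(CC)nc1NC(CC)CC`) gives 2 h and compound 2 (`CCc1nc(-c2ccc(Cl)cc2Cl)c(CC)nc1SC(C)CC`) gives 0.283 h as the lower of the two numbers, a gap beyond the usual scatter. For the measured compounds named here, these two compounds differ in more than one place, and no single-change step has been measured yet. Compound 3 (`CCc1nc(-c2ccc(Cl)cc2Cl)c(CC)nc1NC(CC)CC`) departs from compound 2 in one place: (pentan-3-yl)amino in place of (sec-butyl)sulfanyl on an aromatic carbon (pentan-3-yl)amino stands in place of (sec-butyl)sulfanyl on an aromatic carbon, next to the ring nitrogen and ortho to an ethyl group. Compound 1 also carries (pentan-3-yl)amino and reaches 2 h in this read-out, so a rise beyond the scatter is expected, though with wide uncertainty. The expected size is a 3.2-fold higher number from compound 2 to compound 3 (0.50 log units; beyond the scatter) by this estimate. For compound 3 the estimate is 0.9 h with an expected range from 0.3 h to 2.5 h in this assay for now.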

Compound 3, half-life: 0.283 h
For compound 3 the middle estimate is 3.2-fold (0.50 log units) above the measured one, and the stated range ends above it.
By their numbers in this assay, from the lowest: compounds 2 and 3 (each within the scatter of the next); then compound 1.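

In this assay, (pentan-3-yl)amino in place of (sec-butyl)sulfanyl gives no change at the digits printed from compound 2 to compound 3 (within the scatter), so on the ethyl-bearing core this position does not separate the two groups, despite the change in linking atom and the added hydrogen-bond donor. The step that does separate compounds is ethyl in place of ethoxy on an aromatic carbon, with a 7.1-fold lower number from compound 1 to compound 3 (0.85 log units; beyond the scatter), which ties the higher number of compound 1 to its ethoxy group and not to (pentan-3-yl)amino alone. No supporting measurement bears on why either step reads as it does.

On these data alone, whether (sec-butyl)sulfanyl and (pentan-3-yl)amino also match when ethoxy is present stays open. So does the reading with a longer alkoxy chain at the ethoxy place, or with a cyclic amine such as morpholine in place of (pentan-3-yl)amino.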